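A few compounds are considered here, and "the series" means these few. Any claim that something is new, unique, unknown or untested is made for them only; others in the source may bear on it.

Compound 1 `Cc1ccccc1Nc1nc(SCc2cn(Cc3ccc(Cl)cc3)nn2)nc(-c2ccccc2)c1C#N`: > 64000 nM
Compound 2 `Cc1ccc(Nc2nc(SCc3cn(Cc4ccc(Cl)cc4)nn3)nc(-c3ccccc3)c2C#N)cc1`: 15100 nM

In a functional assay on B16-F10 cells (Mus musculus) for inhibition, read by MTT assay, with a stated time of 72 h (on this read-out higher numbers stand for weaker inhibition and lower numbers for stronger inhibition), compound 1 reaches only a limit of the assay, > 64000 nM. Within the data shown here, compound 2 gives 15100 nM in this assay, the only value here that is a number rather than a limit (the limit of > 64000 nM in this assay, at which 1 of the 2 values shown sits). Among the measured compounds shown here, the step of an at least 4.2-fold lower number from compound 1 to compound 2 (0.62 log units; beyond the scatter) is the one measured step. Compound 3 `N#Cc1c(Nc2ccccc2F)nc(SCc2cn(Cc3ccc(Cl)cc3)nn2)nc1-c1ccccc1` is reached by 2-fluorophenyl in place of 4-methylphenyl on a nitrogen on an aromatic ring. For the measured compounds named here, only that measured step bears on this change: compound 3 carries 2-fluorophenyl where compound 1 carries 2-methylphenyl and compound 2 carries 4-methylphenyl, so the change runs back in the direction of compound 1. A weakening step in this assay is therefore expected, a 2.6-fold higher number from compound 2 to compound 3 (0.42 log units; beyond the scatter). Compound 3 is estimated at 40000 nM, within 15000 nM to 100000 nM, with a fair chance that only a limit is reported.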

Compound 3, half-maximal inhibitory concentration: > 64000 nM
Compound 3 gave a limit, no number; the forecaster's own chance of this, stated with the estimate: 40%; middle value at least 1.6-fold (0.20 log units) from the limit.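

In this assay, putting 2-fluorophenyl in place of 4-methylphenyl on this nitrogen loses the measurable inhibition, an at least 4.2-fold higher number from compound 2 to compound 3 (0.62 log units; beyond the scatter). Compound 3 stands at > 64000 nM, which is a limit and not a number. With 2-methylphenyl and 2-fluorophenyl both ending at a limit, the step between those two cannot be read, and among the three groups only 4-methylphenyl gives a number: the limit of > 64000 nM in this assay, at which 2 of the 3 values shown sit.

The compounds shown leave open whether the gain follows the place of the group on the ring or the methyl group itself, which 4-fluorophenyl would separate. They also leave open how an unsubstituted phenyl or a 4-methoxyphenyl on the same nitrogen would compare with 4-methylphenyl.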